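This account rests on a few compounds, and the source may have more. Where it says the series, first, only, none or still open, it means among the compounds named here.

Working notes on the series. The shared core is seen in compound 2 `O=C(NO)c1cccc(S(=O)(=O)NCc2ccccc2)c1`, which in an ADME assay on isolated protein for inhibition of protein deacetylase HDAC6 (Homo sapiens), read by fluorescence, with stated times of 5 min and 30 min (on this read-out lower numbers stand for stronger inhibition and higher numbers for weaker inhibition), gives 2600 nM. Compound 1 `O=C(NO)c1cccc(S(=O)(=O)N[C@H](C(=O)Nc2ccccc2)c2ccccc2)c1` carries a phenylcarbamoyl group on the saturated chain carbon bound to an aromatic carbon and a sulfonamide nitrogen, and in this assay compound 1 gives 6700 nM. Going by the values given here, compound 2 thus stands with the lowest of the two numbers measured so far, the only step available being a 2.6-fold lower number from compound 1 to compound 2 (0.41 log units; beyond the scatter), a modest one. Compound 3 `O=C(NO)c1cccc(S(=O)(=O)N[C@H](C(=O)NCc2ccccc2)c2ccccc2)c1` remains to be measured. Its change from compound 2 is benzylcarbamoyl in place of hydrogen on a saturated chain carbon bound to an aromatic carbon and a sulfonamide nitrogen, so the same place is occupied again, this time by the benzyl counterpart of the group in compound 1. Among the compounds with values here, the one step that bears on this change is a 2.6-fold lower number from compound 1 to compound 2 (0.41 log units; beyond the scatter), which went in the direction of removing such a group; restoring a closely related group is expected to move the number back by a comparable amount, and for compound 3 the expected step is a 2.1-fold higher number from compound 2 to compound 3 (0.33 log units; beyond the scatter). Compound 3 is therefore estimated at 5500 nM, with a range from 2500 nM to 12000 nM.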

Compound 3, half-maximal inhibitory concentration: 34000 nM
Beside the measured number, compound 3's estimate is 6.2-fold (0.79 log units) below it; measured number above the stated range.
By their numbers in this assay, from the lowest: compound 2; then compound 1; then compound 3.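

In this assay the saturated chain carbon bound to an aromatic carbon and a sulfonamide nitrogen accepts a carbamoyl group far less readily than the phenylcarbamoyl of compound 1 alone suggested: the benzylcarbamoyl change is a 13-fold higher number from compound 2 to compound 3 (1.12 log units; beyond the scatter) and is a large step, whereas removing phenylcarbamoyl gave only a 2.6-fold lower number from compound 1 to compound 2 (0.41 log units; beyond the scatter) as a modest one. The group on the amide-type nitrogen therefore counts in its own right, with benzyl in place of phenyl giving a 5.1-fold higher number from compound 1 to compound 3 (0.71 log units; beyond the scatter) in a pair that differs in that one place only, so the two amides at this carbon cannot be treated as interchangeable. Nothing on hand gives a reason for this loss.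

Both amides give higher numbers than the hydrogen of compound 2, which leaves open whether any group at this carbon can match or improve on hydrogen, and a methyl group or a carboxylic acid there would bear on that. Also open, as far as these compounds go, is whether a longer chain on the amide nitrogen, such as phenethyl, would continue the rise seen from phenyl to benzyl.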